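The source may report more compounds than this note shows. Statements on the series, on what has been measured and on what is new or still open speak of the compounds shown alone.

In a functional assay on SMMC-7721 cells (Homo sapiens) for antiproliferative activity, read by MTT assay, with a stated time of 48 h (on this read-out lower numbers stand for stronger inhibition and higher numbers for weaker inhibition), compound 3 (`COCOC/C1=C/C[C@](C)(CCC=C(C)C)/C=C/[C@@H](OC(=O)C=C(C)C)[C@](C)(O)/C=C/C1=O`) gives 3250 nM and compound 1 (`CC(=O)OC/C1=C/C[C@](C)(CCC=C(C)C)/C=C/[C@@H](OC(=O)C=C(C)C)[C@](C)(O)/C=C/C1=O`) gives 2950 nM as a pair within the scatter of each other. Compound 2 (`CC(C)=CCC[C@]1(C)/C=C/[C@@H](OC(=O)C=C(C)C)[C@](C)(O)/C=C/C(=O)/C(CCl)=C\C1`) gives 840 nM and alone stands apart, which leaves compound 3 at the weaker end of this small set.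

Compound 4 (`CC(C)=CCC[C@]1(C)/C=C/[C@@H](OC(=O)C=C(C)C)[C@](C)(O)/C=C/C(=O)/C(COC(=O)c2ccc([N+](=O)[O-])cc2)=C\C1`) carries (4-nitrophenyl)carbonyl in place of methoxymethyl on an oxygen on a saturated carbon.

The closest evidence is the exchange on that same oxygen, where methoxymethyl in place of acetyl gave a 1.1-fold higher number from compound 1 to compound 3 (0.04 log units; within the scatter) and stayed within the scatter. The two modest steps, a 3.5-fold lower number from compound 1 to compound 2 (0.55 log units; beyond the scatter) and a 3.9-fold higher number from compound 2 to compound 3 (0.59 log units; beyond the scatter), both involve chloro on the chain carbon, a change that compound 4 does not share. They therefore bear on it only weakly. For the measured compounds named here, no measured compound has an aromatic ring in this group, so the larger group is untested and the range must stay wide.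

The expected step is a 1.3-fold lower number from compound 3 to compound 4 (0.11 log units; within the scatter) and no shift beyond the scatter is expected. For compound 4 the estimated value is 2500 nM with an expected range from 1000 nM to 6000 nM as its upper end.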

Compound 4, half-maximal inhibitory concentration: 2560 nM
Estimate against measurement, compound 4: 1.0-fold (0.01 log units) below, within the range that was stated.
By their numbers in this assay, from the lowest: compound 2; then compounds 4, 1 and 3 (each within the scatter of the next).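

In this assay, placing (4-nitrophenyl)carbonyl on the oxygen on a saturated carbon brings the first six-membered aromatic ring of carbon only to this site, yet a 1.3-fold lower number from compound 3 to compound 4 (0.10 log units; within the scatter) and a 1.2-fold lower number from compound 1 to compound 4 (0.06 log units; within the scatter) both stay within the scatter. Compounds 1, 3 and 4 therefore form a single group on this read-out despite the much larger acyl substituent in compound 4, while a 3.0-fold higher number from compound 2 to compound 4 (0.48 log units; beyond the scatter) lies beyond the scatter and leaves compound 2, with chloro on the same saturated chain carbon, as the only compound shown that stands apart from the others. Nothing available explains why the three oxygen-linked groups read alike or why chloro differs.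

As far as these compounds go, whether the separation of compound 2 belongs to chloro alone stays open, as bromo, an amine or a free hydroxyl on the chain carbon would be needed to test it. Also open, from the compounds shown here alone, is whether the flat response on the oxygen extends to other groups there, such as benzoyl without the nitro group, (4-methoxyphenyl)carbonyl or a longer alkyl chain.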